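Thiocarbonyl amine variation in an ortho-aminobenzamide series

This account rests on a few compounds, and the source may have more. Where it says the series, first, only, none or still open, it means among the compounds named here.

Measured compounds:
Compound 1, `CN(C(=S)SCc1ccc(C(=O)Nc2ccccc2N)cc1)c1cccnc1`, gives 26.5% in a functional assay on A-375 cells (Homo sapiens) for antiproliferative activity, read by CCK-8 assay, with a stated time of 72 h, tested at 2 uM; a higher number here means a stronger effect of the compound at the concentration tested, a lower number a weaker effect.
Compound 2, `Nc1ccccc1NC(=O)c1ccc(CSC(=S)N2CCCc3ccccc32)cc1`, gives 26.5% in this assay.

Compound 2 stands level with compound 1 at the digits printed. For the measured compounds named here, the single measured step, no change at the digits printed from compound 1 to compound 2 (within the scatter), exchanged the amine on the thiocarbonyl carbon and left the read-out unchanged within the scatter.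

Compound 3, `Nc1ccccc1NC(=O)c1ccc(CSC(=S)N2CCc3cc(Cl)ccc32)cc1`, is not yet measured. It differs from compound 2 as follows: 5-chloro-2,3-dihydro-1H-indol-1-yl in place of 1,2,3,4-tetrahydroquinolin-1-yl on a thiocarbonyl carbon. Going by the values given here, no measured step covers this exchange. Among the compounds with values here, the only step available, no change at the digits printed from compound 1 to compound 2 (within the scatter), altered the same place on the thiocarbonyl carbon without an effect beyond the scatter, and nothing further is known about a chlorine on that ring system. A step of no size beyond the scatter, a number 1.5 percentage points higher from compound 2 to compound 3 (within the scatter), is therefore expected in this assay. Compound 3 is estimated at 28%, with a range from 12% to 46%.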

Compound 3, a percentage reported as inhibition, at one concentration (the size of the read-out at that concentration, not a potency): 31.9%
Estimate against measurement, compound 3: 3.9 percentage points below; low and high end bracket the measured number.
By their numbers in this assay, from the lowest: compounds 1, 2 and 3 (each within the scatter of the next).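

On the thiocarbonyl carbon, 5-chloro-2,3-dihydro-1H-indol-1-yl gives in this assay a number 5.4 percentage points higher from compound 2 to compound 3 (within the scatter) and a number 5.4 percentage points higher from compound 1 to compound 3 (within the scatter), so a third amine, this one with a five-membered non-aromatic ring and a chlorine, also leaves the read-out within the scatter. Methyl(pyridin-3-yl)amino, 1,2,3,4-tetrahydroquinolin-1-yl and the chlorinated group therefore cannot be told apart at this place, and this now holds for all three pairs rather than one. Nothing available offers an explanation for this lack of separation.

The last exchange alters the ring size and adds the chlorine together, so the unsubstituted 2,3-dihydro-1H-indol-1-yl group is the comparison that would separate the two. Also open, as far as these compounds go, is whether a small open-chain amine such as dimethylamino, or morpholin-4-yl, on the thiocarbonyl carbon would stay level with these three compounds.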